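The compounds below may be only part of what the source reports. "The series", "measured", "known", "first", "only" and "open" are said of these compounds alone.

Among the compounds with values here, in a functional assay on A549 cells (Homo sapiens) for antiproliferative activity, read by MTT assay, with a stated time of 72 h (on this read-out higher numbers stand for weaker inhibition and lower numbers for stronger inhibition), three compounds have numbers so far. Compound 1 `NC1=NC2(CCOCC2)N(OCCCOc2ccccc2)C(N)=N1` gives 1080 nM, compound 3 `COc1ccc(OCCCON2C(N)=NC(N)=NC23CCOCC3)cc1` gives 660 nM, and compound 2 `CC(C)(C)c1ccc(OCCCON2C(N)=NC(N)=NC23CCSCC3)cc1` gives 1 nM, the lowest of the three and beyond the scatter of both others. Compound 4 `NC1=NC2(CCSCC2)N(OCCCOc2ccc(Br)cc2)C(N)=N1` keeps the core of compound 2 and changes one group: bromo in place of tert-butyl on an aromatic carbon. Within the data shown here, only one measured step involves a group on that aromatic ring, a 1.6-fold lower number from compound 1 to compound 3 (0.21 log units; within the scatter), with methoxy in place of hydrogen. Among the measured compounds shown here, that step lies within the scatter, but it sits on the core of compound 1, which differs from the core of compound 2, and no step involving tert-butyl or bromo has been measured. This is weak guidance, so a moderate step is expected rather than a very large one. For the measured compounds named here, with compound 2 at 1 nM, the lowest number so far, the expected direction is upward. The expected change is a 10-fold higher number from compound 2 to compound 4 (1.00 log units; beyond the scatter). For compound 4 the estimated value is 10 nM, with an expected range from 1 nM to 100 nM.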

Compound 4, half-maximal inhibitory concentration: 740 nM
Beside the measured number, compound 4's estimate is 74-fold (1.87 log units) below it; measured number above the stated range.
By their numbers in this assay, from the lowest: compound 2; then compounds 3, 4 and 1 (each within the scatter of the next).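

Replacing tert-butyl with bromo on this aromatic carbon, para to a large group, gives a 740-fold higher number from compound 2 to compound 4 (2.87 log units; beyond the scatter) in this assay, so on the core of compound 2 the choice of group at this position matters greatly. Within the data shown here, the only earlier step involving a group on this ring, a 1.6-fold lower number from compound 1 to compound 3 (0.21 log units; within the scatter), lay within the scatter and sat on a different core, so it gave no sign that a single change here could have so large an effect. Nothing available explains this jump, and the numbers alone show only its size.

From the compounds shown here alone, it remains open whether a low number on the core of compound 2 is particular to tert-butyl or is shared by other groups at this position, such as isopropyl or trifluoromethyl. Going by these compounds, it is also open whether the same exchange of tert-butyl for bromo would have a similar effect on the core of compound 1.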